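An amide heteroaryl swap measured against a cytotoxicity limit

The compounds below may be only part of what the source reports. "The series", "measured", "known", "first", "only" and "open" are said of these compounds alone.

Compound 2 `O=C(COc1ccc(/C=C2\SC(=O)NC2=O)cc1)Nc1ccccn1` is the starting point. In a functional assay on Gurav cells (Homo sapiens) for cytotoxicity, read by sulforhodamine B assay, with a stated time of 48 h (a lower number here means a stronger inhibitor of growth, a higher number a weaker inhibitor of growth), compound 2 gives < 100000 nM, which is a limit of the assay rather than a number. Compound 1 `O=C(COc1ccc(/C=C2\SC(=O)NC2=O)cc1)Nc1ncc([N+](=O)[O-])s1` gives < 100000 nM in this assay, likewise a limit. The step that the two limits leave unreadable from compound 1 to compound 2 cannot be sized, and the limit of < 100000 nM in this assay, at which 2 of the 2 values shown sit, is all the evidence available. Compound 3 `Cc1cc(NC(=O)COc2ccc(/C=C3\SC(=O)NC3=O)cc2)no1` differs from compound 2 by 5-methyl-1,2-oxazol-3-yl in place of pyridin-2-yl on an amide-type nitrogen. Going by the values given here, no measured step bears on this change, so the expected step that the limit leaves unreadable from compound 2 to compound 3 is placed within the scatter, with no direction favoured. Compound 3 is expected to give 60000 nM, in a range from 15000 nM to 100000 nM, most likely again reported only as a limit.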

Compound 3, concentration for total growth inhibition: < 100000 nM
Compound 3 ended at the assay's limit (the forecaster's own chance of this, stated with the estimate: 70%); the middle value is on the limit's open side.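

No step among compound 1, compound 2 and compound 3 can be read, and the result for compound 3 is again only a limit: the limit of < 100000 nM in this assay, at which 3 of the 3 values shown sit.

From the compounds shown here alone, whether the group on the amide-type nitrogen alters the result in this assay remains open.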